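Furan-3-yl for pyridin-3-yl on a dienone side chain

This account rests on a few compounds, and the source may have more. Where it says the series, first, only, none or still open, it means among the compounds named here.

Measured compounds:
compound 1 `CC1=C(/C=C/C(=O)/C=C/c2ccc(C)cc2)C(C)(C)CCC1` gives 21500 nM
compound 2 `CC1=C(/C=C/C(=O)/C=C/c2cccnc2)C(C)(C)CCC1` gives 10200 nM

In a functional assay on PC-3 cells (Homo sapiens) for cytotoxicity, read by sulforhodamine B assay, with a stated time of 48 h (on this read-out higher numbers stand for weaker inhibition and lower numbers for stronger inhibition), compound 2 stands lowest of the two numbers; its nearest neighbour is compound 1, and the step of a 2.1-fold lower number from compound 1 to compound 2 (0.32 log units; beyond the scatter) lies beyond the scatter but is modest. Compound 3 `CC1=C(/C=C/C(=O)/C=C/c2ccoc2)C(C)(C)CCC1` carries the change (furan-3-yl in place of pyridin-3-yl on a double-bonded chain carbon bound to a double-bonded chain carbon). Going by the values given here, the only measured step that bears on it is the swap of the aryl group on the same chain carbon, from compound 1 to compound 2, which moved the number by a modest amount. A second swap of one heteroaryl for another at the same place is therefore expected to move this assay by a similarly small amount at most, in either direction, quite possibly not beyond the scatter. The expected step is a 1.2-fold higher number from compound 2 to compound 3 (0.07 log units; within the scatter). For compound 3 the estimate is 12000 nM, with a range from 5000 nM to 30000 nM.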

Compound 3, half-maximal inhibitory concentration: 50300 nM
Compound 3: middle estimate off by 4.2-fold (0.62 log units), on the low side, outside the stated range (above it).
By their numbers in this assay, from the lowest: compound 2; then compound 1; then compound 3.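

Within this assay, this position proves more sensitive than the earlier pair suggested: furan-3-yl in place of pyridin-3-yl gives a 4.9-fold higher number from compound 2 to compound 3 (0.69 log units; beyond the scatter), a larger step than a 2.1-fold lower number from compound 1 to compound 2 (0.32 log units; beyond the scatter). Furan-3-yl also falls behind the 4-methylphenyl group, with a 2.3-fold higher number from compound 1 to compound 3 (0.37 log units; beyond the scatter), so compound 3 is the weakest of the three, and compound 1 stands between the two compounds that carry a hetero atom in the ring, which rules out a simple split between rings with and without one. No measurement shown here accounts for the difference between the pyridin-3-yl and furan-3-yl groups.

As far as these compounds go, it remains open whether the loss follows the five-membered ring as such, which thiophen-3-yl at the same chain carbon would test. Also open, from the compounds shown here alone, is how the furan-2-yl group, with its ring attached differently, or an amine on the aromatic ring would fare here.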